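Cutting an isopropyl down to methyl on the shared core

The source may report more compounds than this note shows. Statements on the series, on what has been measured and on what is new or still open speak of the compounds shown alone.

Compound 1 `COc1ccc(-c2nnc3nnc(N4CCCCC4)n3n2)cc1` reaches only a limit in a functional assay on BeWo cells (Homo sapiens) for cytotoxicity, read by MTT assay, with a stated time of 72 h (on this read-out higher numbers stand for weaker inhibition and lower numbers for stronger inhibition), giving > 100000 nM. Among the compounds with values here, compound 2 `CC(C)c1nnc2nnc(N3CCCC3)nn12` gives 3430 nM in this assay, and this is the only true number measured here. The other value shown belongs to compound 1 and is a limit of the assay: the limit of > 100000 nM in this assay, at which 1 of the 2 values shown sits. Compound 3 `Cc1nnc2nnc(N3CCCC3)nn12` differs from compound 2 in one place: methyl in place of isopropyl on an aromatic carbon. Within the data shown here, no measured step of this kind exists to lean on, so the change is expected to be small, a 1.5-fold higher number from compound 2 to compound 3 (0.16 log units; within the scatter), toward weaker inhibition or none beyond the scatter. Compound 3 is estimated at 5000 nM, within a range of 1500 nM to 20000 nM.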

Compound 3, half-maximal inhibitory concentration: 5360 nM
Compound 3: the middle estimate sits 1.1-fold (0.03 log units) below what was measured; the measured number falls inside the stated range.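

In this assay, within the data shown here, swapping the group gives a 1.6-fold higher number from compound 2 to compound 3 (0.19 log units; within the scatter), the first step that can be read on the shared core. At this aromatic carbon, isopropyl and methyl therefore cannot be told apart by this read-out, so a small carbon group here can change without a clear effect on cytotoxicity. Nothing at hand explains this result. On these data alone, it remains open whether a longer chain such as hexyl would behave in the same way at this carbon. The same question stands for an amine or a carboxylic acid there.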